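This account rests on a few compounds, and the source may have more. Where it says the series, first, only, none or still open, it means among the compounds named here.

Measured in an assay on CHO-K1 cells for displacement of a labelled ligand from prostaglandin E2 receptor EP1 subtype (Homo sapiens); on this read-out lower numbers stand for stronger inhibition and higher numbers for weaker inhibition:
Compound 1 `CNC(=O)c1cc(C)n(Cc2cc(Cl)ccc2OCc2ccccc2)n1` gives 100 nM.
Compound 2 `Cc1cc(C(=O)Nc2c(F)cccc2F)nn1Cc1cc(Cl)ccc1OCc1ccccc1` gives 10 nM.

For the measured compounds named here, compound 2 stands lowest of the two numbers; the only measured step in the set is a 10-fold lower number from compound 1 to compound 2 (1.00 log units; beyond the scatter).

Compound 3 `Cc1cc(C(=O)NCc2ccccn2)nn1Cc1cc(Cl)ccc1OCc1ccccc1` differs from compound 2 by (pyridin-2-yl)methyl in place of 2,6-difluorophenyl on an amide-type nitrogen. Going by the values given here, the single step of a 10-fold lower number from compound 1 to compound 2 (1.00 log units; beyond the scatter) changes the same amide nitrogen but swaps methyl for an aromatic ring, so it bears only loosely on a (pyridin-2-yl)methyl substituent, which keeps a ring yet adds a methylene link. A modest rise in this assay is therefore expected for compound 3, a 4.0-fold higher number from compound 2 to compound 3 (0.60 log units; beyond the scatter). Compound 3 is estimated at 40 nM, with a range of 10 nM to 160 nM.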

Compound 3, half-maximal inhibitory concentration: 25.1 nM
Compound 3: the middle estimate sits 1.6-fold (0.20 log units) above what was measured; low and high end bracket the measured number.
By their numbers in this assay, from the lowest: compound 2; then compound 3; then compound 1.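

At this amide nitrogen, a ring need not be attached directly: in this assay, (pyridin-2-yl)methyl still gives a 4.0-fold lower number from compound 1 to compound 3 (0.60 log units; beyond the scatter) and so keeps part of the gain over methyl. Against 2,6-difluorophenyl it gives a 2.5-fold higher number from compound 2 to compound 3 (0.40 log units; beyond the scatter) but this step changes both the ring and the link, so neither can be credited alone. Nothing available gives a reason for either step.

Benzyl on the amide nitrogen, or pyridin-2-yl attached directly to it, would separate the two changes. As far as these compounds go, how a longer chain to the pyridin-2-yl ring would read out remains open.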